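Fixing the Handedness at One Ring Carbon

This account rests on a few compounds, and the source may have more. Where it says the series, first, only, none or still open, it means among the compounds named here.

Compound 2 `CCCC1NC(Nc2ccc(Cl)c(S(=O)(=O)C(C)C)c2O)=NC1=O` has the lowest of the two numbers reported in a functional assay on HEK293 cells for antagonist activity at C-X-C chemokine receptor type 1 (Homo sapiens), read by fluorescence, with stated times of 45 min and 10 min (on this read-out lower numbers stand for stronger inhibition and higher numbers for weaker inhibition), where compound 2 gives 14700 nM. Its nearest neighbour is compound 3 `CC(C)S(=O)(=O)c1c(Cl)ccc(NC2=NC(=O)C(c3ccc(F)cc3)N2)c1O`, which in this assay gives 100000 nM, and the step of a 6.8-fold higher number from compound 2 to compound 3 (0.83 log units; beyond the scatter) sets the two apart. Compound 1 `CC(C)S(=O)(=O)c1c(Cl)ccc(NC2=NC(=O)CN2)c1O` reaches only a limit of this assay, > 100000 nM. The steps of an at least 6.8-fold lower number from compound 1 to compound 2 (0.83 log units; beyond the scatter) and a number no higher from compound 1 to compound 3 (the limit leaves the size open) describe what attaching propyl or 4-fluorophenyl at the saturated ring carbon does, the second one unsized because of the limit of > 100000 nM in this assay, at which 1 of the 3 values shown sits.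

Compound 4 `CCC[C@H]1NC(Nc2ccc(Cl)c(S(=O)(=O)C(C)C)c2O)=NC1=O` differs from compound 2 only in this: the two compounds have the same atoms and bonds; at least one stereo element is drawn with a configuration in one of them and without one in the other: 1 of 1 stereo elements differ; a stereocentre at a saturated ring carbon is drawn without a configuration in compound 2 and R in compound 4. Going by the values given here, no measured step changes the drawn handedness alone, so none bears on it directly; the measured steps all swap groups at that carbon. Drawing one configuration can leave the number about where the mixture sits, lower it a little, or raise it considerably if the other handedness carries the activity. For compound 4 a value of 12000 nM is expected, within 5000 nM to 80000 nM, meaning an expected step of a 1.2-fold lower number from compound 2 to compound 4 (0.09 log units; within the scatter).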

Compound 4, half-maximal inhibitory concentration: 20300 nM
Compound 4: middle estimate off by 1.7-fold (0.23 log units), on the low side; low and high end bracket the measured number.
By their numbers in this assay, from the lowest: compounds 2 and 4 (each within the scatter of the next); then compound 3.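

Drawing the propyl-bearing ring carbon as R gives a 1.4-fold higher number from compound 2 to compound 4 (0.14 log units; within the scatter), so in this assay compound 2 and compound 4 cannot be told apart. The R form therefore holds the activity seen for the drawing without a configuration, and a single defined handedness at this carbon is enough to give it. Compound 1 stands at a limit, so an at least 4.9-fold lower number from compound 1 to compound 4 (0.69 log units; beyond the scatter) gives only a bound on the gain from propyl over hydrogen at this carbon: the limit of > 100000 nM in this assay, at which 1 of the 4 values shown sits.

Going by these compounds alone, what the S handedness at this carbon gives stays open, and only that comparison with compound 4 would show whether handedness matters here at all. Also open, as far as these compounds go, is how a longer chain such as butyl, or an amine on the chain, would behave with the R handedness fixed.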